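A few compounds are considered here, and "the series" means these few. Any claim that something is new, unique, unknown or untested is made for them only; others in the source may bear on it.

Measured so far in an ADME assay on HELF cells (Homo sapiens) for cytotoxicity, with a stated time of 3 days; on this read-out lower numbers stand for higher toxicity in this test and higher numbers for lower toxicity in this test:
- Compound 1 `CC(C)C[C@H](NC(=O)[C@]1(Cc2ccccc2)CCN1C(=O)OCc1ccccc1)C(N)=O`: 50000 nM
- Compound 2 `C[C@H](NC(=O)[C@@]1(Cc2ccccc2)CCN1C(=O)OCc1ccccc1)C(=O)NC(C)(C)C`: > 100000 nM, a limit of the assay

Compound 2 has no exact reading, only a limit, > 100000 nM. This places it at the limit of > 100000 nM in this assay, at which 1 of the 2 values shown sits. Compound 1, on the other hand, gives a number, 50000 nM.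

Compound 3 `CC(C)CNC(=O)[C@H](C)NC(=O)[C@@]1(Cc2ccccc2)CCN1C(=O)OCc1ccccc1` shares its atoms with compound 2, joined differently, and the two differ in one place: isobutyl in place of tert-butyl on an amide-type nitrogen. Isobutyl stands in place of tert-butyl on an amide-type nitrogen. For the measured compounds named here, no measured pair of compounds shows what a change of this kind does in this assay, so the expectation rests on little. Going by the values given here, with compound 1 at 50000 nM as the only exact reading, a much lower value is not expected for the new compound. The estimated step of an at least 1.2-fold lower number from compound 2 to compound 3 (0.09 log units; that floor lies within the scatter) is expected to stay within the usual scatter, or to lean slightly towards higher toxicity in this test. The assay may well report only a limit again. For compound 3 the estimate is 80000 nM, with an expected range of 35000 nM to 150000 nM.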

Compound 3, half-maximal cytotoxic concentration: > 100000 nM
Compound 3 gave a limit, no number (the forecaster's own chance of this, stated with the estimate: 50%); middle value at least 1.2-fold (0.09 log units) away from the limit.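

In this assay compound 3 gives > 100000 nM, a limit of the assay and not a number. For the compounds shown here, compound 2 also stands at a limit, so no step between compound 2 and compound 3 can be read. The compounds shown leave open what isobutyl in place of tert-butyl on an amide-type nitrogen does in this assay.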